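Aryl thioether swap from compound 1 to compound 3

The source may hold more compounds than are shown below. What is called first, only, known or untested is meant among the compounds shown, and "the series" means these compounds.

Compound 1 `Cc1cc(C)cc(SCc2ccc(/C=C/C(=O)Nc3ccccc3N)cc2)c1` stands lowest of the two measured numbers in a functional assay on HeLa cells (Homo sapiens) for inhibition, read by CCK-8 assay, with a stated time of 72 h, tested at 8 uM (on this read-out lower numbers stand for less inhibition of growth and higher numbers for more inhibition of growth at the one concentration tested), giving 3.39%. Compound 2 `COc1ccc(SCc2ccc(C(=O)Nc3ccccc3N)cc2)cc1OC` gives 79.9% in this assay, a gap beyond the scatter. Compound 3 `CC(C)(C)c1ccc(SCc2ccc(/C=C/C(=O)Nc3ccccc3N)cc2)cc1` differs from compound 1 by 4-(tert-butyl)phenyl in place of 3,5-dimethylphenyl on a sulfur. Among the measured compounds shown here, no measured pair isolates this change, so its size is unknown; with compound 1 at 3.39%, a step of no more than the usual scatter in either direction is expected. The step of a number 4.6 percentage points higher from compound 1 to compound 3 (within the scatter) is thus expected to be small. Compound 3 is estimated at 8%, with a range from 0% to 30%.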

Compound 3, percent growth inhibition at one concentration: 9.8%
Estimate against measurement, compound 3: 1.8 percentage points below; low and high end bracket the measured number.
By their numbers in this assay, from the lowest: compounds 1 and 3 (each within the scatter of the next); then compound 2.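

In this assay, 4-(tert-butyl)phenyl in place of 3,5-dimethylphenyl on a sulfur gives a number 6.4 percentage points higher from compound 1 to compound 3 (within the scatter). This position therefore accepts both aryl groups without a readable difference at the one concentration tested, and both compounds remain far from the value of compound 2 79.9%. Nothing available explains this outcome.

Among the compounds shown here, compound 2 differs from compound 1 in more than one place, so no step to it can be read. As far as these compounds go, whether a phenyl group carrying an amine or a carboxylic acid on this sulfur would depart from these two values remains open.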